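Sulfone in place of the sulfonamide linker on the ether chain

The source may hold more compounds than are shown below. What is called first, only, known or untested is meant among the compounds shown, and "the series" means these compounds.

Of the compounds shown here, two of a shared core have been tested in a functional assay on HepG2 cells for inhibition of squalene monooxygenase (Homo sapiens); a higher number here means a weaker inhibitor, a lower number a stronger inhibitor. Compound 1 `CCN(C/C=C/C#CC(C)(C)C)Cc1cccc(OCCN(C)S(=O)(=O)Cc2cccs2)c1` gives 200 nM in this assay. Compound 2 `CCN(C/C=C/C#CC(C)(C)C)Cc1cccc(OCCCN(C)S(=O)(=O)c2cccs2)c1` gives 6400 nM in this assay, the highest of the two numbers, reached by a 32-fold higher number from compound 1 to compound 2 (1.51 log units; beyond the scatter). Compound 3 `CCN(C/C=C/C#CC(C)(C)C)Cc1cccc(OCCCS(=O)(=O)c2cccs2)c1` is the unmeasured compound, and it differs from compound 2 by (thiophen-2-yl)sulfonyl in place of methyl((thiophen-2-yl)sulfonyl)amino on a saturated chain carbon, three bonds along the chain from an oxygen on an aromatic ring. Among the compounds with values here, no measured step follows this kind of change: the only step available, a 32-fold higher number from compound 1 to compound 2 (1.51 log units; beyond the scatter), replaces one chain and sulfonyl group with another, so it indicates how strongly this region of the molecule can move the number, but not the direction of the present change. The estimate therefore stays close to compound 2, with a wide range; the expected step is a 1.8-fold lower number from compound 2 to compound 3 (0.26 log units; within the scatter) in this assay. Compound 3 is thus estimated at 3500 nM, expected between 800 nM and 15000 nM.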

Compound 3, half-maximal inhibitory concentration: 290 nM
Compound 3: the middle estimate sits 12-fold (1.08 log units) above what was measured; measured number below the stated range.
By their numbers in this assay, from the lowest: compounds 1 and 3 (each within the scatter of the next); then compound 2.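

Putting (thiophen-2-yl)sulfonyl in place of methyl((thiophen-2-yl)sulfonyl)amino on this saturated chain carbon gives a 22-fold lower number from compound 2 to compound 3 (1.34 log units; beyond the scatter) in this assay, so a change at this one place can undo nearly all of the gap that separated compound 2 from compound 1. Within the data shown here, the remaining comparison, a 1.5-fold higher number from compound 1 to compound 3 (0.16 log units; within the scatter), shows that two different arrangements of chain and sulfonyl group can sit at the same level, which sets compound 2 apart as the only weak member of the three. No measurement at hand gives a reason for the size of this step.

From the compounds shown here alone, whether a longer chain, or an amine or a carboxylic acid in place of the sulfonyl group, would hold this level stays open. So does whether a sulfonamide without the methyl group would behave like compound 2 or like compound 3.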